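The compounds below may be only part of what the source reports. "The series", "measured", "known", "first", "only" and "open" are said of these compounds alone.

In an ADME assay on PBMC cells (Homo sapiens) for cytotoxicity, with a stated time of 72 h (a lower number here means a stronger inhibitor, a higher number a weaker inhibitor), compound 1 `O=C(NO)c1cc(F)c(Cn2nnc(-c3ccco3)n2)c(F)c1` gives > 1000 nM, which is a limit of the assay and not a number. Two relatives were tested in the same way. Compound 2 `Cn1c(Sc2c(F)cc(C(=O)NO)cc2F)nnc1-c1cccs1` gives > 1000 nM, also a limit. Compound 3 `Cn1c(Sc2c(F)cc(C(=O)NO)cc2F)nnc1-c1ncccc1F` gives > 1000 nM, again a limit. The whole set so far therefore comes down to the limit of > 1000 nM in this assay, at which 3 of the 3 values shown sit.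

Compound 4 `O=C(NO)c1cc(F)c(Cn2nnc(-c3ccccn3)n2)c(F)c1` differs from compound 1 in one place, with pyridin-2-yl in place of furan-2-yl on an aromatic carbon. Among the compounds with values here, the only measured step of a similar kind, 3-fluoropyridin-2-yl in place of thiophen-2-yl, is a step that the two limits leave unreadable from compound 2 to compound 3, so it offers no size to carry over and no direction to follow. No change beyond the usual scatter is therefore expected, and the estimated step is a step that the limit leaves unreadable from compound 1 to compound 4. A reading that is again only a limit is the likeliest outcome. For compound 4 the expected value is 1500 nM, with an estimated range from 800 nM to 5000 nM.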

Compound 4, half-maximal inhibitory concentration: > 1000 nM
Compound 4 gave a limit, no number (the forecaster's own chance of this, stated with the estimate: 85%); the middle value lies beyond the limit too.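

Within the data shown here, compound 1 and compound 4 both give only a limit and not a number, so pyridin-2-yl in place of furan-2-yl yields no step that can be read. The compounds shown leave open whether any of them truly differ, since all share one reading: the limit of > 1000 nM in this assay, at which 4 of the 4 values shown sit.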